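A few compounds are considered here, and "the series" means these few. Any claim that something is new, unique, unknown or untested is made for them only; others in the source may bear on it.

Measured compounds in a functional assay for inhibition of transient receptor potential cation channel subfamily V member 1 (Homo sapiens), read by fluorescence and calcium flux; a lower number here means a stronger inhibitor, a higher number a weaker inhibitor:

Compound 1, `COc1cc(-c2cc3c(O)nc(C)nc3cc2C(C)C)ccc1Cl`: 14 nM
Compound 2, `COCCOc1cc(-c2cc3c(O)nc(C)nc3cc2C(C)C)ccc1Cl`: 216 nM
Compound 3, `Cc1nc(O)c2cc(-c3ccc(Cl)c(OCCO)c3)c(C(C)C)cc2n1`: 557 nM

Among these three, compound 3 gives the highest number, so it is the weakest inhibitor of the set. Compound 4, `Cc1nc(O)c2cc(-c3ccc(Cl)c(OCC4CCC4)c3)c(C(C)C)cc2n1`, has not yet been measured; it differs from compound 3 by cyclobutyl in place of hydroxymethyl on a saturated chain carbon bound to an oxygen on an aromatic ring. For the measured compounds named here, three measured steps bear on this change. Lengthening the chain on the oxygen gave a 15-fold higher number from compound 1 to compound 2 (1.19 log units; beyond the scatter) and a 40-fold higher number from compound 1 to compound 3 (1.60 log units; beyond the scatter), both large increases. Replacing the methyl by hydrogen on the chain oxygen gave a 2.6-fold higher number from compound 2 to compound 3 (0.41 log units; beyond the scatter). Compound 4 removes the hydroxyl group entirely and enters a ring of carbon only, so a lower number than compound 3 is expected, by roughly a 5.6-fold lower number from compound 3 to compound 4 (0.75 log units; beyond the scatter). Compound 4 is estimated at 100 nM, in the range 25 nM to 400 nM.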

Compound 4, half-maximal inhibitory concentration: 144 nM
For compound 4 the middle estimate is 1.4-fold (0.16 log units) below the measured one; measured number inside the range.
By their numbers in this assay, from the lowest: compound 1; then compounds 4 and 2 (each within the scatter of the next); then compound 3.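

In this assay a chain without any oxygen of its own on the saturated carbon still costs much of the activity of compound 1 (a 10-fold higher number from compound 1 to compound 4 (1.01 log units; beyond the scatter)), so the drop is not tied to the oxygen in the chains of compound 2 and compound 3. Cyclobutyl recovers part of the loss seen with hydroxymethyl (a 3.9-fold lower number from compound 3 to compound 4 (0.59 log units; beyond the scatter)), while it cannot be told apart from methoxymethyl (a 1.5-fold lower number from compound 2 to compound 4 (0.18 log units; within the scatter)). Nothing available explains these differences.

Still open, from the compounds shown here alone, is whether a single methyl on that carbon would stay closer to compound 1, and how an amine or a carboxylic acid there would behave.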